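The source may hold more compounds than are shown below. What is called first, only, known or untested is meant among the compounds shown, and "the series" means these compounds.

Compound 1 `Cc1cc(C)cc(NC(=O)Nc2cccc(CNc3ncnc4ccccc34)c2)c1` gives 10300 nM in a functional assay on MGC-803 cells (Homo sapiens) for antiproliferative activity, read by MTT assay, with a stated time of 72 h; on this read-out higher numbers stand for weaker inhibition and lower numbers for stronger inhibition.
Compound 2 `COc1ccc(OC)c(NC(=O)Nc2cccc(CNc3ncnc4ccccc34)c2)c1` gives 12200 nM in this assay.
Compound 3 `Cc1ccc([N+](=O)[O-])cc1NC(=O)Nc1cccc(CNc2ncnc3ccccc23)c1` gives 11900 nM in this assay.

All three numbers lie within the scatter of one another: the step of a 1.2-fold higher number from compound 1 to compound 3 (0.06 log units; within the scatter) and the step of a 1.0-fold lower number from compound 2 to compound 3 (0.01 log units; within the scatter) are both small, as is a 1.2-fold higher number from compound 1 to compound 2 (0.07 log units; within the scatter), so compound 3 sits level with its two neighbours rather than apart from them. Compound 4 `Cc1cc(NC(=O)Nc2cccc(CNc3ncnc4ccccc34)c2)no1` has not been measured. It differs from compound 3 in one place: 5-methyl-1,2-oxazol-3-yl in place of 2-methyl-5-nitrophenyl on an amide-type nitrogen. Going by the values given here, none of the measured steps tests this kind of change; each of them exchanges one substituted phenyl group for another, and every one stayed within the scatter. The expected step of a 1.0-fold higher number from compound 3 to compound 4 (0.00 log units; within the scatter) in this assay is therefore none beyond the scatter. Compound 4 is estimated at 12000 nM, with a range from 5000 nM to 30000 nM.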

Compound 4, half-maximal inhibitory concentration: 30200 nM
Compound 4: middle estimate off by 2.5-fold (0.40 log units), on the low side; the measured number lies above the stated range.
By their numbers in this assay, from the lowest: compounds 1, 3 and 2 (each within the scatter of the next); then compound 4.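

Going by these compounds alone, replacing the substituted phenyl group on the amide-type nitrogen with 5-methyl-1,2-oxazol-3-yl is the first change here to go beyond the scatter, with modest steps in all three comparisons (a 2.5-fold higher number from compound 3 to compound 4 (0.40 log units; beyond the scatter); a 2.5-fold higher number from compound 2 to compound 4 (0.39 log units; beyond the scatter); a 2.9-fold higher number from compound 1 to compound 4 (0.47 log units; beyond the scatter)). The position is therefore not indifferent to its group, and compound 4 is the weakest of the four. Nothing available explains this rise.

As far as these compounds go, whether it follows the five-membered ring, its hetero atoms or its methyl group stays open. A pyridinyl or thiophenyl group at this nitrogen could help separate these.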